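A Pyridyl Swap on the Sulfonamide Nitrogen of Compound 2

A few compounds are considered here, and "the series" means these few. Any claim that something is new, unique, unknown or untested is made for them only; others in the source may bear on it.

Among the compounds with values here, compound 2 `CCc1ccccc1N(CC(=O)NCc1ccc(Cl)cc1)S(=O)(=O)c1ccc(C)cc1` gives 11.5 nM in a functional assay on CHO-K1 cells for antagonist activity at prostaglandin E2 receptor EP1 subtype (Homo sapiens), read by FLIPR and calcium flux (a lower number here means a stronger inhibitor, a higher number a weaker inhibitor), the lowest of the three numbers measured so far. The nearest is compound 3 `CCc1ccccc1N(CC(=O)NCc1ccc(C(F)(F)F)cc1)S(=O)(=O)c1ccc(C)cc1`, which gives 209 nM in this assay; the step of an 18-fold higher number from compound 2 to compound 3 (1.26 log units; beyond the scatter) lies beyond the scatter. The furthest is compound 1 `CCc1ccccc1N(CC(=O)NCc1ccc(OC)c(OC)c1)S(=O)(=O)c1ccc(C)cc1`, which gives 282 nM in this assay; the step of a 25-fold lower number from compound 1 to compound 2 (1.39 log units; beyond the scatter) is likewise beyond the scatter, while the step of a 1.3-fold lower number from compound 1 to compound 3 (0.13 log units; within the scatter) lies within it. Compound 4 `Cc1ccc(S(=O)(=O)N(CC(=O)NCc2ccc(Cl)cc2)c2ccccn2)cc1` differs from compound 2 in one place: pyridin-2-yl in place of 2-ethylphenyl on a sulfonamide nitrogen. Within the data shown here, none of the three measured steps touches the sulfonamide nitrogen; each of them changes the group on the saturated chain carbon bound to the amide-type nitrogen, so none of them bears on this change, and no measured compound shows what a pyridin-2-yl at this position does. Among the measured compounds shown here, with no measured step to anchor the change, compound 4 is expected to come out weaker than compound 2, by a 5.2-fold higher number from compound 2 to compound 4 (0.72 log units; beyond the scatter). The estimate for compound 4 in this assay is 60 nM, with a range from 15 nM to 400 nM.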

Compound 4, inhibition constant: < 1450 nM
Compound 4: no number, only a limit (the forecaster's own chance of this, stated with the estimate: 10%); the middle value does not contradict the limit.
By their numbers in this assay, from the lowest: compound 2; then compounds 3 and 1 (each within the scatter of the next).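

In this assay, within the data shown here, compound 4 gives < 1450 nM, which is a limit and not a number, so no step from compound 2 to compound 4 can be read. The compounds shown leave open what pyridin-2-yl in place of 2-ethylphenyl on a sulfonamide nitrogen does to the inhibition constant.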